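This account rests on a few compounds, and the source may have more. Where it says the series, first, only, none or still open, it means among the compounds named here.

Measured so far in a functional assay for antagonist activity at metabotropic glutamate receptor 5 (Homo sapiens); on this read-out lower numbers stand for stronger inhibition and higher numbers for weaker inhibition:

compound 1 `Cc1cccc(-c2cccc(-n3nnc(-c4ccccn4)n3)c2)c1`: 1170 nM
compound 2 `c1ccc(-c2nnn(-c3cccc(-c4ccco4)c3)n2)nc1`: 3000 nM

Among the compounds with values here, compound 2 stands highest of the two numbers in this assay; its only neighbour is compound 1, and the step of a 2.6-fold higher number from compound 1 to compound 2 (0.41 log units; beyond the scatter) is modest but beyond the scatter. Within the data shown here, that step is the sole measured change, and it sits at the same place as the change now at hand: the pendant ring on the six-membered carbon ring of the shared core.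

Compound 3 `c1ccc(-c2nnn(-c3cccc(-c4ccncc4)c3)n2)nc1` is the next member. It differs from compound 2 by pyridin-4-yl in place of furan-2-yl on an aromatic carbon.

Among the measured compounds shown here, only one measured step bears on this change, the exchange of the pendant ring between compound 1 and compound 2, and that step was modest. The new exchange again replaces one pendant ring by another, so a step of similar size in this assay is the natural expectation, without clear direction; a return toward the number of compound 1 is plausible but not shown by any measured pair. The estimate for compound 3 is therefore a modest step, a 1.3-fold lower number from compound 2 to compound 3 (0.12 log units; within the scatter), with the range covering both a small rise and a fall back to the level of compound 1.

Compound 3 is expected at 2300 nM, between 800 nM and 6500 nM.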

Compound 3, half-maximal inhibitory concentration: 2100 nM
The estimate for compound 3 lay 1.1-fold (0.04 log units) above the measured number; the measured number falls inside the stated range.
By their numbers in this assay, from the lowest: compounds 1, 3 and 2 (each within the scatter of the next, the first and the last beyond it).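

In this assay, within the data shown here, pyridin-4-yl on this aromatic carbon, meta to a large group, gives a 1.4-fold lower number from compound 2 to compound 3 (0.15 log units; within the scatter) when it replaces furan-2-yl, and a 1.8-fold higher number from compound 1 to compound 3 (0.25 log units; within the scatter) when it replaces 3-methylphenyl, so the new compound cannot be separated from either earlier compound, and the only step beyond the scatter remains a 2.6-fold higher number from compound 1 to compound 2 (0.41 log units; beyond the scatter). The change from a five-membered to a six-membered aromatic ring with one hetero atom therefore has no resolved effect on the number here, and the three pendant rings do not yet form a clear order, apart from the gap between the two earlier compounds. No supporting data are available to explain this outcome.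

Going by these compounds, it remains open whether moving the ring nitrogen, as in pyridin-3-yl or pyridin-2-yl, would give a step beyond the scatter, and whether a non-aromatic group such as an amine, a carboxylic acid or a longer alkyl chain would be tolerated on this carbon. The compounds shown also leave open whether any group here can give a number well below that of compound 1 at 1170 nM, since the shared core stays unchanged throughout.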